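The source may hold more compounds than are shown below. What is called first, only, known or untested is meant among the compounds shown, and "the series" means these compounds.

Measured so far in an ADME assay on HEK293 cells (Homo sapiens) for antiproliferative activity, read by MTT assay; on this read-out lower numbers stand for stronger inhibition and higher numbers for weaker inhibition:

- Compound 1 `Nc1c(C(=O)N/N=C/c2ccc(Br)cc2)oc2nc(-c3cccs3)cc(C(F)(F)F)c12`: 86000 nM
- Compound 2 `CNC(=O)c1oc2nc(-c3ccccc3)cc(C(F)(F)F)c2c1N`: 62000 nM

Compound 1 has the higher of these two numbers, but the gap to compound 2 lies within the usual scatter of repeated measurements, so the two compounds cannot be ranked. Both values are large numbers on this read-out.

The next compound to be tested is compound 3 `Nc1c(C(=O)NC2CCCC2)oc2nc(-c3cccs3)cc(C(F)(F)F)c12`, which keeps the core of compound 1 and changes one group: a group of 5 heavy atoms (5 carbon; one five-membered non-aromatic ring of carbon only) in place of a group of 9 heavy atoms (7 carbon, 1 nitrogen, 1 bromine; one six-membered aromatic ring of carbon only), on an amide-type nitrogen. A cyclopentyl group therefore replaces the larger bromine-bearing group on the amide-type nitrogen.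

Within the data shown here, no measured pair of compounds isolates this change, so the data give no direct guide to its size or direction. The only support is that the two known values sit within the scatter of each other, so no step beyond the scatter is expected in this assay, in either direction. The expected change is a 1.3-fold lower number from compound 1 to compound 3 (0.12 log units; within the scatter). For compound 3 the estimated value is 65000 nM, with an expected range from 28000 nM to 150000 nM.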

Compound 3, half-maximal inhibitory concentration: 51000 nM
Estimate against measurement, compound 3: 1.3-fold (0.11 log units) above; the measured number falls inside the stated range.
By their numbers in this assay, from the lowest: compounds 3, 2 and 1 (each within the scatter of the next).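

In this assay the amide-type nitrogen of the shared core tolerates a large change of group: replacing the bromine-bearing group of 9 heavy atoms, with its six-membered aromatic ring and its double bond outside aromatic rings, by cyclopentyl gives a 1.7-fold lower number from compound 1 to compound 3 (0.23 log units; within the scatter). This is the only pair shown that differs in one place, so it gives the only direct reading at this position, and that reading shows no step beyond the usual scatter, even though the entering group has no aromatic ring, no double bond outside a ring and no hydrogen-bond acceptor. All three numbers remain large on this read-out, and nothing measured here explains why these two groups read alike.

As far as these compounds go, it remains open whether any group on this nitrogen can move the number beyond the scatter, and a chain carrying an amine, a carboxylic acid or a longer alkyl chain at this place would test that. Also open, from the compounds shown here alone, is how much the other parts of the shared core matter, as this is the only place covered by a single-change pair.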